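The source may hold more compounds than are shown below. What is called first, only, known or untested is meant among the compounds shown, and "the series" means these compounds.

Measured compounds:
- compound 1 `Cc1cc(-c2ccccc2)n(/C(N)=N/S(=O)(=O)c2cc(C)c(Cl)cc2SCc2ccc(C(F)(F)F)cc2)n1`: 0.241 h
- compound 2 `Cc1cc(S(=O)(=O)/N=C(\N)n2nccc2-c2ccccc2)c(SCc2ccc(C(F)(F)F)cc2)cc1Cl`: 0.176 h
- compound 3 `Cc1cc(S(=O)(=O)/N=C(\N)n2nccc2-c2ccccc2)c(SCc2ccccc2C)cc1Cl`: 0.0802 h

In an ADME assay on microsomes from liver (Homo sapiens) for metabolic stability, read by LC-MS, using NADPH, tested at 5 uM (on this read-out higher numbers stand for a longer-lived compound and lower numbers for a shorter-lived compound), compound 1 holds the highest of the three numbers. Compound 2 sits close to it, since a 1.4-fold lower number from compound 1 to compound 2 (0.14 log units; within the scatter), while compound 3 lies furthest away. The step from compound 2 to compound 3 changes the group on the saturated chain carbon bound to a sulfur, and there a 2.2-fold lower number from compound 2 to compound 3 (0.34 log units; beyond the scatter).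

Compound 4 `Cc1cc(-c2ccccc2)n(/C(N)=N/S(=O)(=O)c2cc(C)c(Cl)cc2SCc2ccccc2C(F)(F)F)n1` is not yet measured. It differs from compound 1 at that same place: 2-(trifluoromethyl)phenyl in place of 4-(trifluoromethyl)phenyl on a saturated chain carbon bound to a sulfur. Among the measured compounds shown here, the only measured step at this place is the one from compound 2 to compound 3, and it gave a modest drop; the step from compound 1 to compound 2 lies elsewhere and stays within the scatter. Because a 2.2-fold lower number from compound 2 to compound 3 (0.34 log units; beyond the scatter), a modest decrease in this assay is expected for compound 4, though a different group enters here, so the expectation is uncertain. Compound 4 is estimated at 0.15 h, between 0.07 h and 0.32 h. This expected step is a 1.6-fold lower number from compound 1 to compound 4 (0.21 log units; within the scatter).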

Compound 4, half-life: 0.306 h
Compound 4: middle estimate off by 2.0-fold (0.31 log units), on the low side; the measured number falls inside the stated range.
By their numbers in this assay, from the lowest: compound 3; then compounds 2, 1 and 4 (each within the scatter of the next).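

Exchanging 4-(trifluoromethyl)phenyl for 2-(trifluoromethyl)phenyl on the saturated chain carbon bound to a sulfur gives a 1.3-fold higher number from compound 1 to compound 4 (0.10 log units; within the scatter) in this assay, so the two arrangements of the same atoms cannot be told apart here. The earlier change at this place, a 2.2-fold lower number from compound 2 to compound 3 (0.34 log units; beyond the scatter), swapped one group for a different one on a core without the pyrazole-ring methyl, and this new pair shows that a group named as 2-substituted does not always bring a lower number at this place. Nothing shown here accounts for either result.

As far as these compounds go, whether a plain benzyl, or a ring carrying a nitrile or an amine, would keep the half-life of compound 1 stays open. So does whether 2-methylphenyl would give the same step on the core of compound 1.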